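Bromo to chloro on the pendant aryl of compound 2

This account rests on a few compounds, and the source may have more. Where it says the series, first, only, none or still open, it means among the compounds named here.

Measured so far:
compound 1 `O=C(CCCCC1CCSS1)NCc1cn(CCCCOc2ccc3ccc(=O)oc3c2)nn1` — 75.8%
compound 2 `O=C(CCCCC1CCSS1)NCc1cn(CCCCOc2ccc3cc(-c4ccc(Br)cc4)c(=O)oc3c2)nn1` — 47.6%

In a functional assay on PC-12 cells (Rattus norvegicus) for cytotoxicity, read by MTT assay, with stated times of 3 h and 2 h, tested at 50 uM (a higher number here means a stronger effect of the compound at the concentration tested, a lower number a weaker effect), compound 2 gives the lower of the two numbers; the step of a number 28.2 percentage points lower from compound 1 to compound 2 (beyond the scatter) is modest and beyond the scatter. Compound 3 `O=C(CCCCC1CCSS1)NCc1cn(CCCCOc2ccc3cc(-c4ccc(Cl)cc4)c(=O)oc3c2)nn1` differs from compound 2 by chloro in place of bromo on an aromatic carbon. Within the data shown here, no measured step bears on this exchange: the only step known concerns the arrival of the whole 4-bromophenyl group, not a change of halogen on it. The step of a number 1.4 percentage points higher from compound 2 to compound 3 (within the scatter) is therefore expected to stay within the scatter. For compound 3 a value of 49% is estimated, expected between 35% and 63%.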

Compound 3, a percentage reported as activity, at one concentration (the size of the read-out at that concentration, not a potency): 74.9%
Compound 3: middle estimate off by 25.9 percentage points, on the low side; the whole stated range lies below it.
By their numbers in this assay, from the lowest: compound 2; then compounds 3 and 1 (each within the scatter of the next).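

In this assay, the halogen at this place decides the read-out: a number 27.3 percentage points higher from compound 2 to compound 3 (beyond the scatter), although only one heavy atom is exchanged. The drop seen with 4-bromophenyl therefore does not extend to every 4-halophenyl group: a number 0.9 percentage points lower from compound 1 to compound 3 (within the scatter), so 4-chlorophenyl in place of hydrogen gives no step beyond the scatter. Nothing available explains the difference between chloro and bromo here. Open, as far as these compounds go, is where fluoro or an unsubstituted phenyl ring would fall, and whether bromo alone stands apart from the other groups at this place.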